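This account rests on a few compounds, and the source may have more. Where it says the series, first, only, none or still open, it means among the compounds named here.

Among the compounds with values here, compound 2 `O=[N+]([O-])c1cc(-c2nc(-c3ccc(F)cc3)no2)cc(O)c1O` is one of three compounds measured in a functional assay on the whole organism (liver, strain NMRI) for inhibition, with Mus musculus as the target, with a stated time of 3 h, at a dose of 3 mg/kg by the oral route; on this read-out higher numbers stand for more inhibition at the one dose given (going by the name of the read-out) and lower numbers for less inhibition. In this assay compound 2 gives 12.7%, the second highest of the three numbers. Compound 1 `O=[N+]([O-])c1cc(-c2nc(-c3ccc(Cl)c(Cl)c3)no2)cc(O)c1O` gives 8.8%, and the step of a number 3.9 percentage points higher from compound 1 to compound 2 (within the scatter) lies within the scatter. Compound 3 `NC(=O)c1ccc(-c2noc(-c3cc(O)c(O)c([N+](=O)[O-])c3)n2)cc1` gives 79.2%, and the step of a number 66.5 percentage points higher from compound 2 to compound 3 (beyond the scatter) is large. Compound 4 `CN1CCN(c2noc(-c3cc(O)c(O)c([N+](=O)[O-])c3)n2)CC1` differs from compound 2 by 4-methylpiperazin-1-yl in place of 4-fluorophenyl on an aromatic carbon. Within the data shown here, no measured step swaps out that whole ring, so guidance is indirect: the step of a number 3.9 percentage points higher from compound 1 to compound 2 (within the scatter) shows that one change on the ring did little, while the step of a number 66.5 percentage points higher from compound 2 to compound 3 (beyond the scatter) shows that another change there raised the read-out greatly. Compound 4 is therefore expected to show an uncertain, moderate rise of a number 22.3 percentage points higher from compound 2 to compound 4 (beyond the scatter). The estimate for compound 4 is 35%, within 5% to 70%.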

Compound 4, a percentage reported as inhibition, in the whole organism at one dose (the size of the read-out at that dose, not a potency): 56.8%
For compound 4 the middle estimate is 21.8 percentage points below the measured one; the range from low to high includes it.
By their numbers in this assay, from the lowest: compounds 1 and 2 (each within the scatter of the next); then compound 4; then compound 3.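

Putting 4-methylpiperazin-1-yl in place of 4-fluorophenyl gives a number 44.1 percentage points higher from compound 2 to compound 4 (beyond the scatter), and putting it in place of 3,4-dichlorophenyl gives a number 48 percentage points higher from compound 1 to compound 4 (beyond the scatter). The earlier compounds shown here changed only groups carried on the six-membered aromatic ring of carbon, whereas these steps show that in this assay a large rise at this position does not need that ring. Nothing available explains this rise. The compounds shown leave open which part of the new ring matters. A piperidin-1-yl, a morpholin-4-yl or an open-chain dimethylamino group at this position could help separate the ring nitrogen atoms from the ring itself.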